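Sulfonamide to amide swap on the shared core

The compounds below may be only part of what the source reports. "The series", "measured", "known", "first", "only" and "open" are said of these compounds alone.

For the measured compounds named here, compound 1 `O=S(=O)(NCCNc1nccc(-c2c(-c3cccc(F)c3)nc3sccn23)n1)c1ccc(Cl)cc1` gives 18600 nM in a functional assay on A-375 cells (Homo sapiens) for cytotoxicity, read by MTT assay (on this read-out lower numbers stand for stronger inhibition and higher numbers for weaker inhibition), the highest of the two numbers so far; its nearest neighbour, compound 2 `O=C(NCCNc1nccc(-c2c(-c3cccc(F)c3)nc3sccn23)n1)c1ccccc1`, gives 5060 nM in this assay. Compound 3 `O=C(NCCCNc1nccc(-c2c(-c3cccc(F)c3)nc3sccn23)n1)c1ccc(F)cc1` differs from compound 1 by (((4-fluorophenyl)carbonyl)amino)methyl in place of ((4-chlorophenyl)sulfonyl)amino on a saturated chain carbon, two bonds along the chain from a nitrogen on an aromatic ring. Going by the values given here, the only measured step bearing on this is a 3.7-fold lower number from compound 1 to compound 2 (0.57 log units; beyond the scatter), which also puts a carbonyl in place of a sulfonyl on that amine nitrogen, though with a shorter chain and no fluorine. A drop of similar size is expected here because a 3.7-fold lower number from compound 1 to compound 2 (0.57 log units; beyond the scatter) lies beyond the scatter, so a 3.7-fold lower number from compound 1 to compound 3 (0.57 log units; beyond the scatter) is the estimated step. Compound 3 is estimated at 5000 nM, with a range of 1500 nM to 15000 nM.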

Compound 3, half-maximal inhibitory concentration: 14900 nM
Compound 3: middle estimate off by 3.0-fold (0.47 log units), on the low side; measured number inside the range.
By their numbers in this assay, from the lowest: compound 2; then compounds 3 and 1 (each within the scatter of the next).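

In this assay, an amide in place of the sulfonamide does not by itself bring a gain: (((4-fluorophenyl)carbonyl)amino)methyl in place of ((4-chlorophenyl)sulfonyl)amino gives a 1.2-fold lower number from compound 1 to compound 3 (0.10 log units; within the scatter). The same group in place of benzamido gives a 2.9-fold higher number from compound 2 to compound 3 (0.47 log units; beyond the scatter), so the number at this saturated chain carbon depends on more than the swap of sulfonyl for carbonyl. No evidence on the cause of either step is available.

On these data alone, compound 3 carries the extra methyl and the fluorine together, so the share of each in the step from compound 2 stays open. Also open, as far as these compounds go, is how a longer chain or a terminal carboxylic acid would read here.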